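This account rests on a few compounds, and the source may have more. Where it says the series, first, only, none or still open, it means among the compounds named here.

For the measured compounds named here, compound 1 `Cc1ccc(NC2=CC(=O)c3c(nc4n3[C@H]3OC[C@@H](O)[C@H]3OC4)C2=O)cc1C` is the only member of this small set with a numeric result: in a functional assay on MCF7 cells (Homo sapiens) for inhibition, read by sulforhodamine B assay (on this read-out lower numbers stand for stronger inhibition and higher numbers for weaker inhibition), compound 1 gives 4950 nM. Compound 2 `O=C1C(N2CCCC2)=CC(=O)c2c1nc1n2[C@H]2OC[C@@H](O)[C@H]2OC1` stops at a limit of this assay, > 16000 nM. Compound 3 `O=C1C(N2CCCCC2)=CC(=O)c2c1nc1n2[C@H]2OC[C@@H](O)[C@H]2OC1` also stops at a limit of this assay, > 8000 nM. The two measured steps away from compound 1 both replace the arylamino group with a cyclic amine: an at least 3.2-fold higher number from compound 1 to compound 2 (0.50 log units; beyond the scatter) and an at least 1.6-fold higher number from compound 1 to compound 3 (0.20 log units; that floor lies within the scatter). Between the two cyclic amines a step that the two limits leave unreadable from compound 2 to compound 3, as both sit at limits (the limit of > 16000 nM in this assay, at which 1 of the 3 values shown sits, (the limit of > 8000 nM in this assay, at which 1 of the 3 values shown sits)).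

Compound 4 `CCOc1ccccc1NC1=CC(=O)c2c(nc3n2[C@H]2OC[C@@H](O)[C@H]2OC3)C1=O` keeps the arylamino of compound 1 and changes only the aromatic ring on it: 2-ethoxyphenyl in place of 3,4-dimethylphenyl on an amine nitrogen. The 3,4-dimethylphenyl leaves, the 2-ethoxyphenyl enters, and the amine nitrogen and its double-bonded ring carbon are untouched. Going by the values given here, no measured step tests an exchange of one aryl for another; the steps from compound 1 show only that removing the arylamino altogether raises the number, once beyond the scatter and once within it. For compound 4 a step within the usual scatter is therefore expected, a 1.1-fold higher number from compound 1 to compound 4 (0.05 log units; within the scatter), with a real chance that the result is again only a limit. Compound 4 is estimated at 5500 nM, within a range from 1800 nM to 16000 nM.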

Compound 4, half-maximal inhibitory concentration: > 4000 nM
Compound 4: only a limit was reported (the forecaster's own chance of this, stated with the estimate: 25%); the middle value lies beyond the limit too.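

Compound 4 stops at > 4000 nM, which is a limit of the assay and not a number, so the step from compound 1 to compound 4 cannot be read. The compounds shown leave open how 2-ethoxyphenyl compares with 3,4-dimethylphenyl on the amine nitrogen, and whether any aryl exchange on the shared core changes the result.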